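Adding a hydroxy group to a weak aryl vinyl sulfone

The source may report more compounds than this note shows. Statements on the series, on what has been measured and on what is new or still open speak of the compounds shown alone.

Compound 1 `O=S(=O)(/C=C/c1ccccc1)Cc1ccc(Nc2ncnc3ccccc23)cc1` is the starting point. In a functional assay on U-251 cells (Homo sapiens) (on this read-out lower numbers stand for stronger inhibition of growth and higher numbers for weaker inhibition of growth), compound 1 gives only a limit of the assay, > 100000 nM, not a number. Compound 2 `N#Cc1ccc(/C=C/S(=O)(=O)Cc2ccc(Nc3ncnc4ccccc34)cc2)cc1` carries a cyano group and, in this assay, compound 2 likewise reaches only the limit > 100000 nM. Among the measured compounds shown here, compound 3 `O=S(=O)(/C=C/c1ccc(Cl)cc1Cl)Cc1ccc(Nc2ncnc3ccccc23)cc1`, with a 2,4-dichlorophenyl group, is the one compound with a number: in this assay compound 3 gives 4000 nM. The step from compound 1 to compound 2 is a step that the two limits leave unreadable from compound 1 to compound 2, because of the limit of > 100000 nM in this assay, at which 2 of the 3 values shown sit. The change to compound 3 is an at least 25-fold lower number from compound 1 to compound 3 (1.39 log units; beyond the scatter) and an at least 25-fold lower number from compound 2 to compound 3 (1.39 log units; beyond the scatter).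

Compound 4 `O=S(=O)(/C=C/c1ccc(O)cc1)Cc1ccc(Nc2ncnc3ccccc23)cc1` is not yet measured. It differs from compound 1 by hydroxy in place of hydrogen on an aromatic carbon. For the measured compounds named here, none of the measured steps puts a hydroxy group on this ring, so no step bears on it directly; the only large change seen, the dichlorophenyl of compound 3, is a different kind of group. Since compound 1 stands at a limit, a step from it cannot be read, and a hydroxy group alone gives no reason to expect a large lowering. The estimate for compound 4 is 80000 nM, between 10000 nM and 300000 nM, which would mean an expected step of an at least 1.2-fold lower number from compound 1 to compound 4 (0.09 log units; that floor lies within the scatter).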

Compound 4, concentration for 50% growth inhibition: 300 nM
For compound 4 the middle estimate is 270-fold (2.43 log units) above the measured one; measured number below the stated range.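

In this assay a single hydroxy group, on an aromatic carbon para to a large group, gives an at least 330-fold lower number from compound 1 to compound 4 (2.52 log units; beyond the scatter), so a compound stuck at the assay limit becomes one with a real number. Among the compounds shown here, the group at this place also matters more than the earlier compounds could show: exchanging cyano for hydroxy gives an at least 330-fold lower number from compound 2 to compound 4 (2.52 log units; beyond the scatter), and exchanging the 2,4-dichlorophenyl group, until now the only one with a number, for 4-hydroxyphenyl gives a 13-fold lower number from compound 3 to compound 4 (1.12 log units; beyond the scatter). The first two of these steps are only floors, because each starts from a compound that gives a limit and not a number: the limit of > 100000 nM in this assay, at which 2 of the 4 values shown sit.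

Going by these compounds, it remains open whether the gain needs the hydroxy group itself, or whether a methoxy group or an amine on the same aromatic carbon would give a similar number. On these data alone, it is also open whether a hydroxy group on another carbon of this ring would keep the gain, and whether adding one to the 2,4-dichlorophenyl ring would lower the number further.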